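Chloro for Methylsulfonyl on the Pyridine-Like Core

The source may hold more compounds than are shown below. What is called first, only, known or untested is meant among the compounds shown, and "the series" means these compounds.

Compound 1, `CSc1cc(C)nc(Cl)c1NC(=O)N(Cc1ccc(Oc2ccc(F)cc2)cc1)C1CCCCCC1`: 46 nM
Compound 2, `CSc1nc(C)cc(Cl)c1NC(=O)N(Cc1ccc(Oc2ccc(F)cc2)cc1)C1CCCCCC1`: 12 nM
Compound 3, `Cc1cc(S(C)(=O)=O)c(NC(=O)N(Cc2ccc(Oc3ccc(F)cc3)cc2)C2CCCCCC2)c(S(C)(=O)=O)n1`: 45 nM

In an assay for inhibition of acyl-CoA:cholesterol acyltransferase (Oryctolagus cuniculus), using microsomes (on this read-out higher numbers stand for weaker inhibition and lower numbers for stronger inhibition), compound 3 gives 45 nM, the second highest of the three numbers shown. Among the measured compounds shown here, compound 1 sits within the scatter of compound 3, whereas compound 2 lies a larger distance away; the only single-point step recorded is a 3.8-fold lower number from compound 1 to compound 2 (0.58 log units; beyond the scatter), which swaps the arrangement of substituents on the same core.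

Compound 4, `Cc1cc(S(C)(=O)=O)c(NC(=O)N(Cc2ccc(Oc3ccc(F)cc3)cc2)C2CCCCCC2)c(Cl)n1`, differs from compound 3 by chloro in place of methylsulfonyl on an aromatic carbon. For the measured compounds named here, no measured pair traces this exact exchange, so the expectation rests on the general spread seen so far: the three measured compounds span only a modest interval, and the one recorded step is modest. Compound 4 carries chloro next to the ring nitrogen, as compound 1 does, and compound 1 and compound 3 give numbers within the scatter of each other. Compound 4 is therefore expected to stay near compound 3, with a step of a 1.1-fold lower number from compound 3 to compound 4 (0.05 log units; within the scatter). The estimate for compound 4 in this assay is 40 nM, within a range of 15 nM to 110 nM.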

Compound 4, half-maximal inhibitory concentration: 30 nM
Estimate against measurement, compound 4: 1.3-fold (0.12 log units) above, within the range that was stated.
By their numbers in this assay, from the lowest: compound 2; then compounds 4, 3 and 1 (each within the scatter of the next).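

In this assay, chloro in place of methylsulfonyl on the aromatic carbon next to the ring nitrogen gives a 1.5-fold lower number from compound 3 to compound 4 (0.18 log units; within the scatter) and so stays within the scatter, even though both hydrogen-bond acceptors of that group are gone. With chloro held in place, methylsulfonyl in place of methylsulfanyl gives a 1.5-fold lower number from compound 1 to compound 4 (0.19 log units; within the scatter) and is likewise not separated from the scatter. Only a 2.5-fold higher number from compound 2 to compound 4 (0.40 log units; beyond the scatter) goes beyond it, but that step exchanges the whole substituted aromatic group on the amide-type nitrogen and so singles out no one substituent.

Nothing at hand gives a reason for these numbers.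
Going by these compounds, whether an amine or a carboxylic acid on that same carbon would keep the number near that of compound 4 remains open.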